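Fluoro Added to Compound 1: Expected Effect on Agonist Potency

The source may report more compounds than this note shows. Statements on the series, on what has been measured and on what is new or still open speak of the compounds shown alone.

Measured so far:
- Compound 1 `Cc1ccc(Nc2nc(N)nc(COc3cccc(N4CCCC4=O)c3)n2)cc1Cl` gives 820 nM in an assay on COS-7 cells for agonist activity at Free fatty acid receptor 1 (Homo sapiens), read by scintillation counting and inositol phosphate accumulation, with a stated time of 90 min; on this read-out higher numbers stand for an effect only at larger amounts of compound and lower numbers for an effect already at smaller amounts.
- Compound 2 `Cc1ccc(Nc2nc(N)nc(COc3cccc(N4CCCC4=O)c3C)n2)cc1Cl` gives 11100 nM.
- Compound 3 `Cc1ccc(Nc2nc(N)nc(COc3ccc(Cl)c(N4CCCC4=O)c3)n2)cc1Cl` gives 2450 nM.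

Among these three, compound 1 has the lowest number, so it acts at the smallest amount. Its nearest neighbour is compound 3, reached through a 3.0-fold higher number from compound 1 to compound 3 (0.48 log units; beyond the scatter), and the furthest is compound 2, reached through a 14-fold higher number from compound 1 to compound 2 (1.13 log units; beyond the scatter). Both of those steps added a single group to an aromatic carbon, and both raised the number, one modestly and one by a large amount.

Compound 4 `Cc1ccc(Nc2nc(N)nc(COc3cc(F)cc(N4CCCC4=O)c3)n2)cc1Cl` has not yet been measured. It differs from compound 1 by fluoro in place of hydrogen on an aromatic carbon. For the measured compounds named here, the two measured steps are the only guide, and they point in the same direction: a substituent added to an aromatic carbon has so far made the number higher. Fluoro is the smallest of the three groups added, so a loss like the modest one seen with chloro is more plausible than the large one seen with methyl, and a step within the scatter cannot be ruled out.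

Compound 4 is therefore expected to give 1300 nM in this assay, with a plausible range from 500 nM to 3500 nM. This estimate corresponds to an expected 1.6-fold higher number from compound 1 to compound 4 (0.20 log units; within the scatter).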

Compound 4, half-maximal effective concentration: 1800 nM
Compound 4: middle estimate off by 1.4-fold (0.14 log units), on the low side, and the stated range covers the measured number.
By their numbers in this assay, from the lowest: compound 1; then compounds 4 and 3 (each within the scatter of the next); then compound 2.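

Even fluoro, which brings a single heavy atom, is not neutral on this carbon, meta to the 2-oxopyrrolidin-1-yl group: the measured change is a 2.2-fold higher number from compound 1 to compound 4 (0.34 log units; beyond the scatter), so more compound is needed for the same effect. The methyl and chloro steps had shown a cost only on other carbons of this ring, so the result extends the pattern to a third carbon and to the smallest group tried, and among the compounds shown no group on this ring improves on the plain hydrogen of compound 1. No measurement shown offers an explanation for this rise in the number.

The compounds shown leave open how a larger or different group, such as methoxy, an amine or a carboxylic acid, would behave on this same carbon, and so whether any replacement here could lower the number rather than raise it. They also leave open whether fluoro on the carbons carrying methyl in compound 2 or chloro in compound 3 would give a step of this modest size or one more like those groups gave.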